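Whole-animal inhibition: from compound 1 to compound 3

This account rests on a few compounds, and the source may have more. Where it says the series, first, only, none or still open, it means among the compounds named here.

compound 1 `COc1cccc([C@H]2O[C@H](CC(=O)NCC(=O)O)C(=O)N(CC(C)(C)CO)c3ccc(Cl)cc32)c1OC` — 14%
compound 2 `COc1cccc([C@H]2O[C@H](CC(=O)N3CCC(CC(=O)O)CC3)C(=O)N(CC(C)(C)COC(C)=O)c3ccc(Cl)cc32)c1OC` — 81%

In a functional assay on the whole organism for inhibition, with Rattus norvegicus as the target, at a dose of 10 mg/kg by the oral route (a lower number here means less inhibition, a higher number more inhibition at the dose given (going by the name of the read-out)), compound 1 gives 14%, the lowest of the two numbers shown. Compound 2 gives 81%, a gap beyond the scatter, but the two compounds differ in more than one place, so only their two values can be set side by side. Compound 3 `COc1cccc([C@H]2O[C@H](CC(=O)NC(CC(C)C)C(=O)O)C(=O)N(CC(C)(C)CO)c3ccc(Cl)cc32)c1OC` differs from compound 1 in a single place: isobutyl in place of hydrogen on a saturated chain carbon bound to an amide-type nitrogen and a carbonyl carbon. Among the compounds with values here, no measured pair isolates this change, so its effect is unknown. A modest upward step a number 16 percentage points higher from compound 1 to compound 3 (beyond the scatter) is expected, with the direction uncertain. Compound 3 is therefore estimated at 30%, in the range 5% to 65%.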

Compound 3, a percentage reported as inhibition, in the whole organism at one dose (the size of the read-out at that dose, not a potency): 14%
Estimate against measurement, compound 3: 16 percentage points above, within the range that was stated.
By their numbers in this assay, from the lowest: compounds 1 and 3 (each within the scatter of the next); then compound 2.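

In this assay, within the data shown here, isobutyl in place of hydrogen on a saturated chain carbon bound to an amide-type nitrogen and a carbonyl carbon gives no change at the digits printed from compound 1 to compound 3 (within the scatter) at this dose, the first step here that isolates a single change. At this carbon, then, the added isobutyl does not move the read-out on the background of compound 1. Nothing measured here bears on why this is so. The compounds shown leave open whether another group on this carbon, such as an amine, a carboxylic acid or a longer chain, would shift the read-out. They also leave open whether isobutyl would have the same effect on the background of compound 2.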